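The source may hold more compounds than are shown below. What is called first, only, known or untested is meant among the compounds shown, and "the series" means these compounds.

Measured compounds:
compound 1, `CCN1CCN(Cc2c(OC)cc(Oc3cccc(Nc4ccccc4)c3)cc2OC)CC1`, > 20000 nM
compound 2, `COc1cc(Oc2cccc(Nc3ccccc3)c2)cc(OC)c1CNCc1ccc(Br)cc1`, 11200 nM
compound 3, `COc1cc(Oc2cccc(Nc3ccccc3)c2)cc(OC)c1CNC(C)C`, > 20000 nM

In a functional assay on SW-620 cells (Homo sapiens) for inhibition, read by MTT assay, with a stated time of 72 h (a lower number here means a stronger inhibitor, a higher number a weaker inhibitor), compound 1 gives > 20000 nM, which is a limit of the assay, not a number. Compound 3 likewise gives only a limit, > 20000 nM. Compound 2 is the only one of the three with a number, 11200 nM. Where compound 1 stands is therefore known only as a limit; of the three values, (the limit of > 20000 nM in this assay, at which 2 of the 3 values shown sit), so the series as a whole is weak in this assay.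

The step followed here goes from compound 1 to compound 4, `COc1cc(Oc2cccc(Nc3ccccc3)c2)cc(OC)c1CNCc1ccc(F)cc1`. The change is (4-fluorobenzyl)amino in place of 4-ethylpiperazin-1-yl on a saturated chain carbon bound to an aromatic carbon.

Of the measured steps, the closest is the one to the (4-bromobenzyl)amino analogue: an at least 1.7-fold lower number from compound 1 to compound 2 (0.25 log units; that floor lies within the scatter). The other two steps are less informative: a step that the two limits leave unreadable from compound 1 to compound 3, and an at least 1.7-fold higher number from compound 2 to compound 3 (0.25 log units; that floor lies within the scatter). Compound 4 carries a (4-fluorobenzyl)amino group, which stands nearer to compound 2 than to compound 3 in kind, so the expected step is a modest lowering from the limit of compound 1, with the floor of that step already inside the scatter.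

Compound 4 is estimated at 14000 nM, range 6000 nM to 35000 nM, which means an expected step of an at least 1.4-fold lower number from compound 1 to compound 4 (0.15 log units; that floor lies within the scatter), with a real chance that the assay again reports only a limit.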

Compound 4, half-maximal inhibitory concentration: 6770 nM
Estimate against measurement, compound 4: 2.1-fold (0.32 log units) above; measured number inside the range.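

On a saturated chain carbon bound to an aromatic carbon, (4-fluorobenzyl)amino in place of 4-ethylpiperazin-1-yl gives the first step from the piperazine in this assay that is readable beyond the scatter: an at least 2.9-fold lower number from compound 1 to compound 4 (0.47 log units; beyond the scatter). The comparison of a benzyl group with isopropyl on the amine nitrogen now also clears the scatter, where the bromo analogue gave only a floor within it, with 4-fluorobenzyl in place of isopropyl giving an at least 2.9-fold lower number from compound 3 to compound 4 (0.47 log units; beyond the scatter). Fluoro in place of bromo on an aromatic carbon gives a 1.7-fold lower number from compound 2 to compound 4 (0.22 log units; within the scatter), so the two halogen-bearing benzylamino compounds are not separated in this assay, and the gain over the other two amines cannot be tied to one halogen.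

Going by these compounds, the true size of the steps from compound 1 and compound 3 stays open, since neither compound gives a number, only a limit: the limit of > 20000 nM in this assay, at which 2 of the 4 values shown sit. Also open, on these data alone, is whether an unsubstituted benzyl group, a 4-methoxybenzyl group or a longer chain such as 2-phenylethyl on the same amine nitrogen would give a value separable from these two.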